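The source may hold more compounds than are shown below. What is called first, only, known or untested is meant among the compounds shown, and "the series" means these compounds.

In an ADME assay on HEK293 cells (Homo sapiens) for cytotoxicity, read by MTT assay, with a stated time of 72 h (a higher number here means a weaker inhibitor, a lower number a stronger inhibitor), compound 1 `O=C(CN1CCN(C(=O)c2ccccc2)CC1)N1CCN(CCCc2c[nH]c3ccc(F)cc23)CC1` gives 148000 nM. Compound 2 `COc1ccc2[nH]cc(CCCN3CCN(C(=O)CN4CCN(C(=O)c5ccccc5)CC4)CC3)c2c1` gives > 200000 nM, which is a limit of the assay and not a number. This is the limit of > 200000 nM in this assay, at which 1 of the 2 values shown sits, so compound 2 has no exact position on the scale.

Compound 3 `COc1ccc2[nH]cc(CCCN3CCN(C(=O)CN4CCN(C(=O)c5cccc(Cl)c5)CC4)CC3)c2c1` differs from compound 2 by one change, chloro in place of hydrogen on an aromatic carbon, turning benzoyl into (3-chlorophenyl)carbonyl. Among the compounds with values here, only one measured step is available, an at least 1.3-fold higher number from compound 1 to compound 2 (0.13 log units; that floor lies within the scatter), and it swaps fluoro for methoxy in a different group. Within the data shown here, no measured compound carries a chloro group. Among the measured compounds shown here, with only that step to go on, no shift beyond the scatter is expected in this assay, and neither direction is favoured.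

For compound 3, the expected value is about 180000 nM, with an estimated range from 90000 nM to 350000 nM. This estimate corresponds to an expected at least 1.1-fold lower number from compound 2 to compound 3 (0.04 log units; that floor lies within the scatter).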

Compound 3, half-maximal inhibitory concentration: 143000 nM
Beside the measured number, compound 3's estimate is 1.3-fold (0.10 log units) above it; the measured number falls inside the stated range.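

Compound 3 gives the first exact number for a compound with the methoxy group on the shared core in this assay, whereas compound 2 has only a limit of the assay, not a number: the limit of > 200000 nM in this assay, at which 1 of the 3 values shown sits.

Replacing hydrogen with chloro, which turns phenyl into 3-chlorophenyl, gives an at least 1.3-fold lower number from compound 2 to compound 3 (0.14 log units; that floor lies within the scatter). This step is only a floor, so the data show no shift beyond the scatter, though they cannot fix the true size of the change.

On these data alone, whether an amine or a nitrile on this same aromatic carbon would move the number beyond the scatter remains open. Also open, as far as these compounds go, is whether chloro would behave the same way on another carbon of this ring, or on the core of compound 1, which carries fluoro instead of methoxy.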